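Swapping the Anilino Ring of Compound 2

This account rests on a few compounds, and the source may have more. Where it says the series, first, only, none or still open, it means among the compounds named here.

Within the data shown here, in a functional assay on PC-3 cells (Homo sapiens) for cytotoxicity, read by MTT assay, with a stated time of 72 h (on this read-out lower numbers stand for stronger inhibition and higher numbers for weaker inhibition), compound 2 `Nc1cccc(Nc2nc3ccccc3nc2S(=O)(=O)c2ccc(Br)cc2)c1` gives 9010 nM, the lower of the two numbers measured so far. Compound 1 `COc1ccc(S(=O)(=O)c2nc3ccccc3nc2Nc2ccc(Cl)cc2)cc1` gives 31800 nM in this assay, a higher number that lies beyond the usual scatter. Compound 3 `O=S(=O)(c1ccc(Br)cc1)c1nc2ccccc2nc1Nc1ccc(Cl)cc1` is not yet measured; it differs from compound 2 in one place: 4-chlorophenyl in place of 3-aminophenyl on a nitrogen on an aromatic ring. Among the measured compounds shown here, compound 1 carries the same 4-chlorophenyl group but a different ring on the sulfonyl side, so no measured pair settles this step directly. An upward move of moderate size is expected a 2.2-fold higher number from compound 2 to compound 3 (0.35 log units; beyond the scatter). Compound 3 is estimated at 20000 nM, between 6000 nM and 60000 nM.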

Compound 3, half-maximal inhibitory concentration: 7460 nM
Compound 3: the middle estimate sits 2.7-fold (0.43 log units) above what was measured; measured number inside the range.
By their numbers in this assay, from the lowest: compounds 3 and 2 (each within the scatter of the next); then compound 1.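

In this assay, the change on the nitrogen barely registers: a 1.2-fold lower number from compound 2 to compound 3 (0.08 log units; within the scatter) shows that 3-aminophenyl and 4-chlorophenyl cannot be told apart here. Among these compounds, by contrast, bromo in place of methoxy on an aromatic carbon gives a 4.3-fold lower number from compound 1 to compound 3 (0.63 log units; beyond the scatter), the first look at that change on its own. No available evidence explains either result. From the compounds shown here alone, it remains open whether a carboxylic acid on the ring carried by that nitrogen would shift the number. Going by these compounds, it is also open whether bromo in place of methoxy gives a similar step with 3-aminophenyl on the nitrogen.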